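This account rests on a few compounds, and the source may have more. Where it says the series, first, only, none or still open, it means among the compounds named here.

Going by the values given here, compound 3 `C/C(=N\Nc1nc(-c2cc3ccccc3o2)cs1)c1cc2ccccc2o1` gives 25600 nM in a functional assay on MCF7 cells (Homo sapiens) for antiproliferative activity (a higher number here means a weaker inhibitor, a lower number a stronger inhibitor), the highest of the three numbers measured so far. Compound 1 `C/C(=N\Nc1nc(-c2ccc(C)cc2)cs1)c1cc2ccccc2o1` gives 11100 nM and compound 2 `C/C(=N\Nc1nc(-c2ccccc2)cs1)c1cc2ccccc2o1` gives 8490 nM; the two steps of a 2.3-fold higher number from compound 1 to compound 3 (0.36 log units; beyond the scatter) and a 3.0-fold higher number from compound 2 to compound 3 (0.48 log units; beyond the scatter) both run upward and are modest, whereas a 1.3-fold lower number from compound 1 to compound 2 (0.12 log units; within the scatter) stays within the scatter. Compound 4 `C/C(=N\Nc1nc(C)cs1)c1cc2ccccc2o1` differs from compound 3 by methyl in place of 1-benzofuran-2-yl on an aromatic carbon. Among the compounds with values here, no measured step removes the aryl group altogether; the two that bear on the change are those in which 1-benzofuran-2-yl took the place of 4-methylphenyl or of phenyl, each raising the number modestly. Reversing that exchange argues for a somewhat lower number, though a methyl is not an aryl, and the step within the scatter between compound 1 and compound 2 shows that this part of the molecule does not always move the read-out. Compound 4 is therefore expected to show a modest downward step of a 2.1-fold lower number from compound 3 to compound 4 (0.33 log units; beyond the scatter), with an estimated 12000 nM and a range from 4000 nM to 40000 nM.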

Compound 4, half-maximal inhibitory concentration: 4890 nM
The estimate for compound 4 lay 2.5-fold (0.39 log units) above the measured number; the range from low to high includes it.
By their numbers in this assay, from the lowest: compounds 4, 2 and 1 (each within the scatter of the next, the first and the last beyond it); then compound 3.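

At this position, next to the ring nitrogen, an aryl group proves unnecessary for the read-out in this assay: methyl in place of 1-benzofuran-2-yl gives a 5.2-fold lower number from compound 3 to compound 4 (0.72 log units; beyond the scatter). Methyl in place of 4-methylphenyl gives a 2.3-fold lower number from compound 1 to compound 4 (0.36 log units; beyond the scatter), whereas methyl in place of phenyl gives a 1.7-fold lower number from compound 2 to compound 4 (0.24 log units; within the scatter), so compound 4 cannot be told apart from compound 2. The earlier compounds shown here compared only aryl groups with one another; these steps show that a group without a ring can match phenyl here. Nothing given here accounts for these steps.

The compounds shown leave open whether an amine, a carboxylic acid or a longer chain at this position would go beyond the scatter of compound 4. They also leave open whether hydrogen alone would hold the number at this level.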